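The source may report more compounds than this note shows. Statements on the series, on what has been measured and on what is new or still open speak of the compounds shown alone.

Working notes on the series.

Compound 1 `Fc1ccc(-c2nn3c(NC4CCCC4)cccc3c2-c2ccnc(NC3CCCC3)n2)cc1` carries a cyclopentylamino group on the shared core. In an ADME assay on Vero cells (Chlorocebus sabaeus) for cytotoxicity (on this read-out higher numbers stand for lower toxicity in this test and lower numbers for higher toxicity in this test), compound 1 gives only a limit of the assay, > 160000 nM. Compound 2 `CC(C)COc1ccc(-c2nn3ccc(NC4CCCC4)cc3c2-c2ccnc(NC3CCCC3)n2)cc1` places an isobutoxy-bearing aryl group in the same series. In this assay compound 2 gives 27000 nM. Compound 3 `Fc1ccc(-c2nn3c(NC4CCCC4)cc(NC4CCCC4)cc3c2-c2ccnc(NC3CCCC3)n2)cc1` adds a second cyclopentylamino group to compound 1. In this assay compound 3 gives only a limit of the assay, > 40000 nM. The step from compound 1 to compound 3, a step that the two limits leave unreadable from compound 1 to compound 3, cannot be read because both values are limits, the limit of > 160000 nM in this assay, at which 1 of the 3 values shown sits, and (the limit of > 40000 nM in this assay, at which 1 of the 3 values shown sits). Compound 3 therefore stands only as a limit on the numbers shown, with one further limit beside it and the single number given by compound 2.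

Compound 4 `CC(C)Sc1cc(NC2CCCC2)cc2c(-c3ccnc(NC4CCCC4)n3)c(-c3ccc(F)cc3)nn12` differs from compound 3 by isopropylsulfanyl in place of cyclopentylamino on an aromatic carbon. For the measured compounds named here, no measured step covers an exchange of this kind; the only step, from compound 1 to compound 3, is unreadable, so no direction beyond the scatter is expected in this assay for compound 4. The step from compound 3 to compound 4 is estimated as a number no higher from compound 3 to compound 4 (the limit leaves the size open). Compound 4 is expected to give 40000 nM, within 15000 nM to 160000 nM, in this assay.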

Compound 4, half-maximal cytotoxic concentration: > 40000 nM
Compound 4 gave a limit, no number; the forecaster's own chance of this, stated with the estimate: 40%; the middle value lies on the limit itself.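

Compound 3 and compound 4 both stand as limits in this assay, so no step between them can be read: the limit of > 40000 nM in this assay, at which 2 of the 4 values shown sit.

The compounds shown leave open the size and direction of the exchange of cyclopentylamino for isopropylsulfanyl on this aromatic carbon, as only compound 2 gives a number.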